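This account rests on a few compounds, and the source may have more. Where it says the series, first, only, none or still open, it means among the compounds named here.

Compounds measured in a functional assay on DU-145 cells (Homo sapiens) for antiproliferative activity, read by MTT assay, with a stated time of 48 h; on this read-out lower numbers stand for stronger inhibition and higher numbers for weaker inhibition:
- Compound 1 `C/C(=C\CC/C(C)=C/CC[C@@H]1[C@@]2(C)CCC(=O)C(C)(C)[C@H]2CC[C@@]1(C)O)CC/C=C(\C)C(=O)OCc1cn(-c2cccc(C)c2)nn1`: 137000 nM
- Compound 2 `C/C(=C\CC/C(C)=C/CC[C@@H]1[C@@]2(C)CCC(=O)C(C)(C)[C@H]2CC[C@@]1(C)O)CC/C=C(\C)C(=O)OCc1cn(-c2ccccc2C)nn1`: > 150000 nM (a limit)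
- Compound 3 `C/C(=C\CC/C(C)=C/CC[C@@H]1[C@@]2(C)CCC(=O)C(C)(C)[C@H]2CC[C@@]1(C)O)CC/C=C(\C)C(=O)OCc1cn(-c2cccc(Br)c2)nn1`: > 150000 nM (a limit)

Compound 3 has no number, only the limit > 150000 nM. This is the limit of > 150000 nM in this assay, at which 2 of the 3 values shown sit.

Compound 4 `C/C(=C\CC/C(C)=C/CC[C@@H]1[C@@]2(C)CCC(=O)C(C)(C)[C@H]2CC[C@@]1(C)O)CC/C=C(\C)C(=O)OCc1cn(-c2cccc(Cl)c2)nn1` has chloro in place of bromo on an aromatic carbon. The closest measured change is bromo in place of methyl, an at least 1.0-fold higher number from compound 1 to compound 3 (0.03 log units; that floor lies within the scatter). The other step reaching compound 3, a step that the two limits leave unreadable from compound 2 to compound 3, adds nothing. No step beyond the scatter is therefore expected in this assay, in either direction. The estimated step is a number no higher from compound 3 to compound 4 (the limit leaves the size open). The expected value for compound 4 is 150000 nM, with an estimated range of 90000 nM to 250000 nM.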

Compound 4, half-maximal inhibitory concentration: 103000 nM
The estimate for compound 4 lay 1.5-fold (0.16 log units) above the measured number, and the stated range covers the measured number.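

In this assay chloro in place of bromo on this aromatic carbon yields a measured number rather than a limit, yet neither floor clears the scatter (an at least 1.4-fold lower number from compound 3 to compound 4 (0.16 log units; that floor lies within the scatter); an at least 1.4-fold lower number from compound 2 to compound 4 (0.16 log units; that floor lies within the scatter)). Chloro and methyl at this position cannot be told apart (a 1.3-fold lower number from compound 1 to compound 4 (0.12 log units; within the scatter)). Compound 2 and compound 3 stand only at a limit: the limit of > 150000 nM in this assay, at which 2 of the 4 values shown sit.

Still open, as far as these compounds go, is whether an amine or a carboxylic acid at this position on the phenyl ring would give a step beyond the scatter.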